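The source may hold more compounds than are shown below. What is called first, only, known or untested is meant among the compounds shown, and "the series" means these compounds.

Measured in an ADME assay on HeLa Rh cells (Homo sapiens) for cytotoxicity, read by microscopy; on this read-out higher numbers stand for lower toxicity in this test and lower numbers for higher toxicity in this test:
- Compound 1 `COc1cc(CC(O)c2ccc(-c3ccc(C=O)cc3)cc2)c([N+](=O)[O-])cc1OC`: > 245000 nM. This is a limit of the assay, not a number.
- Compound 2 `COc1cc(CC(O)c2ccc(-c3ccc(C)cc3)cc2)c([N+](=O)[O-])cc1OC`: 4700 nM
- Compound 3 `COc1cc(CC(O)c2ccc(-c3cccc(C#N)c3)cc2)c([N+](=O)[O-])cc1OC`: 5200 nM

Compound 2 shares the low end of these results with compound 3, and the two cannot be told apart: a 1.1-fold higher number from compound 2 to compound 3 (0.04 log units; within the scatter). Compound 4 `COc1cc(CC(O)c2ccc(-c3cccc(Cl)c3)cc2)c([N+](=O)[O-])cc1OC` has not yet been measured. It differs from compound 2 by 3-chlorophenyl in place of 4-methylphenyl, para to a large group: 3-chlorophenyl in place of 4-methylphenyl on an aromatic carbon.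

The closest guide is the swap of the same 4-methylphenyl for 3-cyanophenyl, which stayed within the scatter: a 1.1-fold higher number from compound 2 to compound 3 (0.04 log units; within the scatter). The two large steps, an at least 52-fold lower number from compound 1 to compound 2 (1.71 log units; beyond the scatter) and an at least 47-fold lower number from compound 1 to compound 3 (1.67 log units; beyond the scatter), both start from a limit and remove the 4-formylphenyl group, which is absent from both compound 2 and compound 4. They therefore say little here.

No step beyond the scatter is expected in this assay, and the estimate is a 1.1-fold higher number from compound 2 to compound 4 (0.03 log units; within the scatter). For compound 4 the expected value is 5000 nM, with an estimated range of 2000 nM to 13000 nM.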

Compound 4, half-maximal cytotoxic concentration: 5900 nM
The estimate for compound 4 lay 1.2-fold (0.07 log units) below the measured number; the measured number falls inside the stated range.
By their numbers in this assay, from the lowest: compounds 2, 3 and 4 (each within the scatter of the next). At a limit, above all of these: compound 1.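

In this assay, chloro and cyano on the 3-position of this phenyl ring cannot be told apart, a 1.1-fold higher number from compound 3 to compound 4 (0.05 log units; within the scatter), and 3-chlorophenyl matches 4-methylphenyl just as 3-cyanophenyl did, a 1.3-fold higher number from compound 2 to compound 4 (0.10 log units; within the scatter), so three differently substituted rings now give one level of cytotoxicity. The 4-formylphenyl ring of compound 1 stays alone against this third group too, with an at least 41-fold lower number from compound 1 to compound 4 (1.61 log units; beyond the scatter). The value of compound 1 is a limit, not a number: the limit of > 245000 nM in this assay, at which 1 of the 4 values shown sits.

From the compounds shown here alone, what remains open is whether the same group gives the same result at either ring position, as a 4-chlorophenyl or 3-formylphenyl ring would show. Also open, going by these compounds, is whether a ring carrying an amine or a carboxylic acid would stay with compounds 2, 3 and 4 or move toward compound 1.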